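This account rests on a few compounds, and the source may have more. Where it says the series, first, only, none or still open, it means among the compounds named here.

Measured compounds:
compound 1, `COc1cc2c(Oc3ccc(NC(=O)/C=C/S(=O)(=O)c4ccccc4F)cc3F)ccnc2cc1OCCCN1CCN(C)CC1`, 150 nM
compound 2, `COc1cc2c(Oc3ccc(NC(=O)/C=C/S(=O)(=O)c4ccccc4OC)cc3F)ccnc2cc1OCCCN1CCN(C)CC1`, 270 nM

In a functional assay on HT-29 cells (Homo sapiens) for cytotoxicity, read by MTT assay, with a stated time of 72 h (a higher number here means a weaker inhibitor, a lower number a stronger inhibitor), compound 1 gives 150 nM, and compound 2 gives 270 nM. For the measured compounds named here, the one measured step, a 1.8-fold higher number from compound 1 to compound 2 (0.26 log units; within the scatter), leaves the two numbers within the scatter of each other, so compound 2 stands level with compound 1 rather than apart from it.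

Compound 3, `COc1cc2c(Oc3ccc(NC(=O)/C=C/S(=O)(=O)c4ccccc4OC)cc3F)ccnc2cc1OCCCN1CCC(C)CC1`, keeps everything in compound 2 except the group at the end of the propyl chain: 4-methylpiperidin-1-yl in place of 4-methylpiperazin-1-yl on a saturated chain carbon, three bonds along the chain from an oxygen on an aromatic ring. Going by the values given here, no measured step touches this part of the structure; the only step on record concerns the aromatic substituent and was itself within the scatter. There is therefore no basis in these numbers for expecting a shift in either direction, and the expected step of no change at the digits printed from compound 2 to compound 3 (within the scatter) is none beyond the scatter. Compound 3 is thus estimated at 270 nM in this assay, with a range from 110 nM to 650 nM.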

Compound 3, half-maximal inhibitory concentration: 1960 nM
Compound 3: the middle estimate sits 7.3-fold (0.86 log units) below what was measured, outside the stated range (above it).
By their numbers in this assay, from the lowest: compounds 1 and 2 (each within the scatter of the next); then compound 3.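

For the compounds shown here, the end of the propyl chain proved sensitive in this assay: 4-methylpiperidin-1-yl in place of 4-methylpiperazin-1-yl gives a 7.3-fold higher number from compound 2 to compound 3 (0.86 log units; beyond the scatter) and so lies beyond the scatter, whereas the only earlier step, on the aromatic substituent, stayed within it. The two groups have the same number of heavy atoms and the same six-membered ring, and differ only in that a ring nitrogen of the one is a carbon in the other. Nothing available explains why this exchange moves the number.

Going by these compounds, it remains open whether the same exchange would give a step of similar size with the fluoro group of compound 1 in place of the methoxy. Also open, on these data alone, is where other groups at the chain end, such as morpholin-4-yl or dimethylamino, or a longer chain, would fall relative to compound 2 and compound 3.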